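The source may hold more compounds than are shown below. What is called first, only, known or untested is meant among the compounds shown, and "the series" means these compounds.

Working notes on the series.

Compound 1 `COc1ccccc1Nc1nc(SCc2ccc(C(F)(F)F)cc2)nc2ccccc12` reaches only the limit of > 50000 nM in a functional assay on MCF7 cells (Homo sapiens) for cytotoxicity, read by MTT assay, with a stated time of 72 h (on this read-out lower numbers stand for stronger inhibition and higher numbers for weaker inhibition), a bound rather than a number (the limit of > 50000 nM in this assay, at which 1 of the 3 values shown sits). Two neighbours replace the same group on the nitrogen on an aromatic ring. Compound 2 `FC(F)(F)c1ccc(CSc2nc(Nc3cccc(C(F)(F)F)c3)c3ccccc3n2)cc1` gives 15300 nM in this assay , and compound 3 `FC(F)(F)c1ccc(CSc2nc(Nc3ccc(Cl)cc3)c3ccccc3n2)cc1` gives 21500 nM. The corresponding steps are an at least 3.2-fold lower number from compound 1 to compound 2 (0.51 log units; beyond the scatter) and an at least 2.3-fold lower number from compound 1 to compound 3 (0.36 log units; beyond the scatter); between the two replacements, a 1.4-fold higher number from compound 2 to compound 3 (0.15 log units; within the scatter).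

Compound 4 `COc1ccc(Nc2nc(SCc3ccc(C(F)(F)F)cc3)nc3ccccc23)cc1OC` is the untested member of the set. Against compound 1 the change is 3,4-dimethoxyphenyl in place of 2-methoxyphenyl on a nitrogen on an aromatic ring. Both measured steps away from the 2-methoxyphenyl of compound 1 moved the number downward, but they introduce groups of a different kind from the one entering here, so their bearing on compound 4 is loose. A small downward move from the bound of compound 1 is the expectation, possibly no measurable number at all.

Compound 4 is estimated at 30000 nM, with a range of 12000 nM to 80000 nM. That estimate corresponds to an expected step of an at least 1.6-fold lower number from compound 1 to compound 4 (0.22 log units; that floor lies within the scatter).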

Compound 4, half-maximal inhibitory concentration: > 50000 nM
Compound 4: only a limit was reported; the forecaster's own chance of this, stated with the estimate: 35%; at least 1.6-fold (0.22 log units) between middle value and limit.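

In this assay, compound 4 gives only a limit and not a number, as compound 1 does: the limit of > 50000 nM in this assay, at which 2 of the 4 values shown sit.

The step between those two compounds cannot be read, but the two measured neighbours now give readable comparisons: an at least 2.3-fold higher number from compound 3 to compound 4 (0.36 log units; beyond the scatter), and an at least 3.2-fold higher number from compound 2 to compound 4 (0.51 log units; beyond the scatter). Among the four compounds, both groups carrying methoxy on the nitrogen on an aromatic ring, 2-methoxyphenyl and 3,4-dimethoxyphenyl, sit on the higher-number side of 4-chlorophenyl and 3-(trifluoromethyl)phenyl, with no compound shown going against this.

As far as these compounds go, how far apart compound 1 and compound 4 truly lie stays open. Also open, from the compounds shown here alone, is whether a phenyl group bearing a hydroxyl or a dimethylamino group in this place would give a number in this assay.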